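Pyridin-3-yl Carbamate in Place of a Fluorophenyl Carbamate

This account rests on a few compounds, and the source may have more. Where it says the series, first, only, none or still open, it means among the compounds named here.

Compound 1 `CCCCOc1ccc(CNC(=O)Oc2ccc(F)cc2F)cc1` gives 8.7 nM in an assay on H4 cells for inhibition of Fatty-acid amide hydrolase 1 (Homo sapiens); a higher number here means a weaker inhibitor, a lower number a stronger inhibitor.
Compound 2 `CCCCOc1ccc(CNC(=O)Oc2ccccc2F)cc1` gives 9.2 nM in this assay.

Compound 2 stands beside compound 1 with both numbers within the scatter of each other; the step of a 1.1-fold higher number from compound 1 to compound 2 (0.02 log units; within the scatter) shows that much. Compound 3 `CCCCOc1ccc(CNC(=O)Oc2cccnc2)cc1` differs from compound 2 by pyridin-3-yl in place of 2-fluorophenyl on an oxygen next to a carbonyl group. Among the measured compounds shown here, no measured step covers an exchange of this kind, and the one step known, a 1.1-fold higher number from compound 1 to compound 2 (0.02 log units; within the scatter), touches only the fluoro, so the ring exchange itself has no precedent here. Compound 3 is therefore expected to give 10 nM, in a range of 3 nM to 35 nM. The expected step of a 1.1-fold higher number from compound 2 to compound 3 (0.04 log units; within the scatter) is not expected to exceed the scatter.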

Compound 3, half-maximal inhibitory concentration: 6.1 nM
Compound 3: middle estimate off by 1.6-fold (0.21 log units), on the high side; measured number inside the range.
By their numbers in this assay, from the lowest: compounds 3, 1 and 2 (each within the scatter of the next).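

Among the compounds shown here, on an oxygen next to a carbonyl group, the earlier compounds had varied only a fluoro, whereas here the whole ring is exchanged: pyridin-3-yl in place of 2-fluorophenyl gives a 1.5-fold lower number from compound 2 to compound 3 (0.18 log units; within the scatter) in this assay. Pyridin-3-yl in place of 2,4-difluorophenyl gives a 1.4-fold lower number from compound 1 to compound 3 (0.15 log units; within the scatter) in the same assay, so a ring with one hetero atom and no fluoro stays within the scatter of both fluorinated rings. Nothing available explains why these exchanges leave the number within the scatter.

Going by these compounds, whether a pyridin-4-yl or a cyclohexyl on the same oxygen would also stay within the scatter remains open.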